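Swapping the phenyl of compound 3

This account rests on a few compounds, and the source may have more. Where it says the series, first, only, none or still open, it means among the compounds named here.

Compound 1 `COc1ccc(-c2c[nH]c(=O)n2-c2cc(OC)c(OC)c(OC)c2)cc1[N+](=O)[O-]`: "not determined" (no result reported)
Compound 2 `COc1ccc(-c2cn(C(=O)Nc3cc(OC)c(OC)c(OC)c3)c(=O)n2-c2cc(OC)c(OC)c(OC)c2)cc1O`: "not determined" (no result reported)
Compound 3 `COc1cc(-n2c(-c3ccccc3)cn(C(C)=O)c2=O)cc(OC)c1OC`: > 50000 nM

In a functional assay on MCF7 cells (Homo sapiens) for cytotoxicity, read by MTT assay, with a stated time of 48 h (a lower number here means a stronger inhibitor, a higher number a weaker inhibitor), compound 3 gives > 50000 nM as its result, which is a limit and not a number. Among the compounds with values here, compounds 1 and 2 have no number to compare, so no measured step serves as a guide. Compound 4 `COc1ccc(-c2cn(C(C)=O)c(=O)n2-c2cc(OC)c(OC)c(OC)c2)cc1N` carries 3-amino-4-methoxyphenyl in place of phenyl on an aromatic carbon of the shared core. In this assay a large step of an at least 160-fold lower number from compound 3 to compound 4 (2.22 log units; beyond the scatter) is expected, toward stronger inhibition. This expectation is a judgement from the structural change, with only the limit of compound 3 at > 50000 nM as its measured starting point. Compound 4 is expected at an estimated 300 nM (20 nM to 10000 nM).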

Compound 4, half-maximal inhibitory concentration: 43400 nM
Compound 4: the middle estimate sits 140-fold (2.16 log units) below what was measured; the measured number lies above the stated range.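

With 3-amino-4-methoxyphenyl on this aromatic carbon, compound 4 gives 43400 nM in this assay. The change amounts to an at least 1.1-fold lower number from compound 3 to compound 4 (0.06 log units; that floor lies within the scatter), so any gain that can be stated is small, and a larger one is not excluded. Compound 3 stands at a limit and not at a number, so the true size of the step stays unknown: the limit of > 50000 nM in this assay, at which 1 of the 4 values shown sits.

Among the compounds shown with the acetyl group, the amino and methoxy groups occur only together, so the share of each stays open. On these data alone, how a carboxylic acid or a nitrile on this phenyl would read also stays open.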